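The source may report more compounds than this note shows. Statements on the series, on what has been measured and on what is new or still open speak of the compounds shown alone.

Measured so far in an ADME assay on MDBK cells (Bos taurus) for cytotoxicity; on this read-out lower numbers stand for higher toxicity in this test and higher numbers for lower toxicity in this test:
- Compound 1 `Clc1ccccc1Cn1ccc2nc(-c3ccccc3)nc-2c1`: > 100000 nM, a limit of the assay
- Compound 2 `Clc1cccc(Cn2ccc3nc(-c4ccccc4)nc-3c2)c1`: > 100000 nM, a limit of the assay
- Compound 3 `C(=C/c1ccccc1)\Cn1ccc2nc(-c3ccccc3)nc-2c1`: 78000 nM

Within the data shown here, compound 3 stands at 78000 nM, the only actual number. Compound 1 and compound 2 both rest on (the limit of > 100000 nM in this assay, at which 2 of the 3 values shown sit).

Compound 4 `c1ccc(-c2nc3ccn(Cc4ccncc4)cc-3n2)cc1` carries pyridin-4-yl in place of 2-phenylethenyl on a saturated chain carbon bound to an aromatic nitrogen.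

Two measured steps change the same place and also leave 2-phenylethenyl in compound 3. They are an at least 1.2-fold lower number from compound 1 to compound 3 (0.10 log units; that floor lies within the scatter) and an at least 1.2-fold lower number from compound 2 to compound 3 (0.10 log units; that floor lies within the scatter). From the compounds shown here alone, both give only floors, so their true size is unknown. The third step is a step that the two limits leave unreadable from compound 1 to compound 2, which adds no size. Among the measured compounds shown here, no measured compound carries pyridin-4-yl, so the estimate borrows from compound 1 and compound 2, which also hold a six-membered aromatic ring at this place. Compound 1 stands at > 100000 nM, a limit of the assay. Compound 2 stands at > 100000 nM, also a limit of the assay.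

No step beyond the scatter is therefore expected in this assay, and any drift would more likely be towards a higher number. The expected step is a 1.3-fold higher number from compound 3 to compound 4 (0.11 log units; within the scatter). The estimate for compound 4 is 100000 nM, with an expected range of 45000 nM to 200000 nM.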

Compound 4, half-maximal cytotoxic concentration: > 100000 nM
Compound 4: a limit, no number; the forecaster's own chance of this, stated with the estimate: 65%; the middle value sits exactly at the limit.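

Pyridin-4-yl brings the first ring with a hetero atom, and the first hydrogen-bond acceptor, to the place on a saturated chain carbon bound to an aromatic nitrogen, and in this assay compound 4 still ends at a limit, not at a number: the limit of > 100000 nM in this assay, at which 3 of the 4 values shown sit.

Among these compounds, the one readable step is an at least 1.2-fold higher number from compound 3 to compound 4 (0.10 log units; that floor lies within the scatter), so this change gives only a floor and its true size stays unknown. Among the compounds shown here, the steps to compound 4 from compound 1 and from compound 2 cannot be read, so pyridin-4-yl cannot be ranked against either chlorophenyl group, and the series shows only that this ring nitrogen brings no measurable number into the read-out.

For the compounds shown here, how far compound 1, compound 2 and compound 4 lie from one another stays open, as does whether the single number of compound 3 goes with the double bond of 2-phenylethenyl or with something else in that group. Also open, from the compounds shown here alone, is whether an amine or a carboxylic acid at this place, or a longer chain on the aromatic nitrogen, would give a number in this assay.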